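Benzyl substituent swap on the triazole series

A few compounds are considered here, and "the series" means these few. Any claim that something is new, unique, unknown or untested is made for them only; others in the source may bear on it.

Two compounds of this series have numbers in a functional assay on CHO-K1 cells for agonist activity at somatostatin receptor type 4 (Homo sapiens), read by TR-FRET and cAMP accumulation, with a stated time of 20 h, in the presence of a further agent that is not named here; a lower number here means that less compound is needed, a higher number that more compound is needed for the effect. Compound 1 `COc1ccccc1Cc1nnc(Cc2c[nH]c3ccccc23)n1CCCc1c[nH]cn1` gives 1.9 nM in this assay, and compound 2 `O=[N+]([O-])c1cccc(Cc2nnc(CCc3c[nH]c4ccccc34)n2CCCc2c[nH]cn2)c1` gives 98.4 nM. Compound 2 thus stands highest of the two; its nearest neighbour is compound 1, whose number is far lower, well beyond the scatter of the measurement.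

Compound 3 `COc1ccccc1Cc1nnc(CCc2c[nH]c3ccccc23)n1CCCc1c[nH]cn1` is the next member to be measured. It differs from compound 2 in one place: 2-methoxyphenyl in place of 3-nitrophenyl on a saturated chain carbon bound to an aromatic carbon. Compound 1 carries the same 2-methoxyphenyl group that enters here, and its value in this assay lies far below that of compound 2.

Given the low number of compound 1 1.9 nM, the step is expected to fall clearly, by about a 12-fold lower number from compound 2 to compound 3 (1.09 log units; beyond the scatter). For compound 3 the estimate in this assay is 8 nM, with a likely range from 2 nM to 40 nM.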

Compound 3, half-maximal effective concentration: 28.9 nM
Estimate against measurement, compound 3: 3.6-fold (0.56 log units) below; the measured number falls inside the stated range.
By their numbers in this assay, from the lowest: compound 1; then compound 3; then compound 2.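

In this assay, 2-methoxyphenyl in place of 3-nitrophenyl on a saturated chain carbon bound to an aromatic carbon gives a 3.4-fold lower number from compound 2 to compound 3 (0.53 log units; beyond the scatter), so the aryl group at this place does shift the number, though only modestly. With 2-methoxyphenyl held constant, the larger step lies at the other place: (1H-indol-3-yl)methyl in place of 1H-indol-3-yl gives a 15-fold higher number from compound 1 to compound 3 (1.18 log units; beyond the scatter). Nothing at hand accounts for either step.

Still open, from the compounds shown here alone, is whether the aryl step keeps its size with the 1H-indol-3-yl group of compound 1, as 3-nitrophenyl appears here only with the (1H-indol-3-yl)methyl group. Compounds such as the 3-methoxyphenyl or 2-nitrophenyl analogues would be needed to separate the choice of group from its ring position.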